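This account rests on a few compounds, and the source may have more. Where it says the series, first, only, none or still open, it means among the compounds named here.

Measured so far in an ADME assay on MT2 cells (Homo sapiens) for cytotoxicity, read by XTT assay, with a stated time of 4 days; a lower number here means that less compound is tolerated, a higher number that more compound is tolerated
Compound 1 `Cc1cc(/C=C/C#N)cc(C)c1Oc1ccc([N+](=O)[O-])c(Nc2ccc(C#N)cc2)c1` gives > 100000 nM (a limit of the assay)
Compound 2 `Cc1cc(/C=C/C(=O)O)cc(C)c1Oc1ccc(N)c(Nc2ccc(C#N)cc2)n1` gives 15700 nM
Compound 3 `Cc1cc(/C=C/C#N)cc(C)c1Oc1ccc(N)c(Nc2ccc(C#N)cc2)c1` gives 8830 nM

Compound 3 and compound 2 lie within the scatter of each other, while compound 1 is known only as a limit. Compound 4 `Cc1cc(/C=C/C#N)cc(C)c1Oc1cc(Nc2ccc(C#N)cc2)c(N)cc1N` differs from compound 3 by one change: amino in place of hydrogen on an aromatic carbon. For the measured compounds named here, the only measured step that bears on it is an at least 11-fold lower number from compound 1 to compound 3 (1.05 log units; beyond the scatter), a large step in which amino replaced nitro. In compound 4 the new amino replaces hydrogen instead. A much smaller step toward a lower number is expected in this assay. The estimated step is a 1.8-fold lower number from compound 3 to compound 4 (0.25 log units; within the scatter). The estimate for compound 4 is 5000 nM, with an expected range from 1500 nM to 20000 nM.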

Compound 4, half-maximal cytotoxic concentration: 18900 nM
Estimate against measurement, compound 4: 3.8-fold (0.58 log units) below; measured number inside the range.
By their numbers in this assay, from the lowest: compounds 3, 2 and 4 (each within the scatter of the next, the first and the last beyond it). At a limit, above all of these: compound 1.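

In this assay, amino in place of hydrogen on this aromatic carbon, para to the (4-cyanophenyl)amino group, gives a 2.1-fold higher number from compound 3 to compound 4 (0.33 log units; beyond the scatter), so slightly more compound is tolerated. The number thus moves the opposite way from the step for amino in place of nitro, an at least 11-fold lower number from compound 1 to compound 3 (1.05 log units; beyond the scatter), where the starting value is a limit. Nothing available accounts for this difference.

On these data alone, whether a methyl group, a methoxy group or a chlorine atom on this carbon would move the number the same way remains open. So does the effect of this amino group on the core of compound 2.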